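The source may report more compounds than this note shows. Statements on the series, on what has been measured and on what is new or still open speak of the compounds shown alone.

Of the compounds shown here, two with a shared core have been measured in an ADME assay on HEK-293T cells (Homo sapiens) for inhibition, read by MTT assay, with a stated time of 48 h; a higher number here means a weaker inhibitor, a lower number a stronger inhibitor. Compound 1 `COc1cc(CN2C(=O)S/C(=C\c3ccc4[nH]c(-c5cc(OC)c(OC)c(OC)c5)nc4c3)C2=O)cc(OC)c1OC` gives 16600 nM in this assay. Among the measured compounds shown here, compound 2 `COc1ccc(-c2nc3cc(/C=C4\SC(=O)N(Cc5cc(OC)c(OC)c(OC)c5)C4=O)ccc3[nH]2)cc1OC` gives 6760 nM in this assay, the lowest of the two numbers, and the only step between them, a 2.5-fold lower number from compound 1 to compound 2 (0.39 log units; beyond the scatter), is a hydrogen in place of a methoxy on an aromatic carbon.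

Compound 3 `COc1cc(-c2nc3cc(/C=C4\SC(=O)N(Cc5cc(OC)c(OC)c(OC)c5)C4=O)ccc3[nH]2)ccc1OCC(C)C` has not yet been measured in this assay. It differs from compound 2 by isopropyl in place of hydrogen on a saturated chain carbon bound to an oxygen on an aromatic ring; cut one bond further out, the change reads methoxy to isobutoxy. For the measured compounds named here, no measured step concerns this kind of change: the one step in hand, from a removed methoxy on an aromatic carbon, is of another sort and gives no direct guide. With only that to go on, a step no larger than the scatter is expected, in either direction, so the number for compound 3 is expected to sit near that of compound 2, with the step of a 1.1-fold lower number from compound 2 to compound 3 (0.05 log units; within the scatter) as the estimate. Compound 3 is therefore estimated at 6000 nM, between 2000 nM and 20000 nM.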

Compound 3, half-maximal inhibitory concentration: 6650 nM
Beside the measured number, compound 3's estimate is 1.1-fold (0.04 log units) below it; the range from low to high includes it.
By their numbers in this assay, from the lowest: compounds 3 and 2 (each within the scatter of the next); then compound 1.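

In this assay the change from methoxy to isobutoxy gives a 1.0-fold lower number from compound 2 to compound 3 (0.01 log units; within the scatter) so compound 2 and compound 3 cannot be told apart, and this position, on a saturated chain carbon bound to an oxygen on an aromatic ring, carries isopropyl in place of hydrogen with no shift beyond the scatter. Among the compounds shown here, the only earlier step (a 2.5-fold lower number from compound 1 to compound 2 (0.39 log units; beyond the scatter)) was of another kind, a hydrogen in place of a methoxy on an aromatic carbon, and it lay beyond the scatter, so it gave no reading of what happens when the methoxy stays and its chain grows. No supporting measurement accompanies these compounds to account for this flat result, which therefore stands as an observation only.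

The compounds shown leave open whether a chain on this oxygen ending in an amine or a carboxylic acid, or a longer chain than isobutyl, would also stay within the scatter. They also leave open whether a free hydroxyl in place of this methoxy would do the same, since a single step is all that speaks for this position.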